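This account rests on a few compounds, and the source may have more. Where it says the series, first, only, none or still open, it means among the compounds named here.

Measured compounds:
compound 1, `C#Cc1cn([C@@H]2O[C@H](CO)[C@@H](O)[C@H]2O)c2ncnc(OC)c12`, 3490 nM in a functional assay on CEM-DNR-bulk cells (Homo sapiens), read by MTT assay, with a stated time of 72 h; on this read-out higher numbers stand for weaker inhibition and lower numbers for stronger inhibition;
compound 2, `COc1ncnc2c1c(-c1ccco1)cn2[C@@H]1O[C@H](CO)[C@@H](O)[C@H]1O`, 160 nM in this assay.

Of these two numbers, compound 1 gives the higher one, and the nearest measured neighbour is compound 2, reached by a 22-fold lower number from compound 1 to compound 2 (1.34 log units; beyond the scatter). That step changes the ethynyl group and says nothing about the part of the core that is altered next.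

Compound 3, `C#Cc1cn([C@@H]2O[C@H](CO)[C@@H](O)[C@H]2O)c2ncnc(N(C)C)c12`, is not yet measured in this assay. It differs from compound 1 in one place: dimethylamino in place of methoxy on an aromatic carbon. Among the compounds with values here, no measured step in this set touches that position, so the expectation for compound 3 rests on the structural change alone, with the single measured step giving no guidance on its size or direction. Since the alteration is a small one at a single aromatic carbon of the core, a step in this assay of modest size is expected, most plausibly toward a somewhat higher number, though a change within the scatter cannot be ruled out.

The estimate for compound 3 in this assay is 6000 nM, within 1500 nM to 25000 nM, which corresponds to an expected step of a 1.7-fold higher number from compound 1 to compound 3 (0.24 log units; within the scatter).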

Compound 3, half-maximal inhibitory concentration: 240 nM
Beside the measured number, compound 3's estimate is 25-fold (1.40 log units) above it; the whole stated range lies above it.
By their numbers in this assay, from the lowest: compounds 2 and 3 (each within the scatter of the next); then compound 1.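

In this assay, replacing methoxy with dimethylamino on the aromatic carbon of the six-membered ring with 2 nitrogen gives a 15-fold lower number from compound 1 to compound 3 (1.16 log units; beyond the scatter), so this carbon of the core, which the earlier step left untouched, also has a large bearing on the read-out. The ethynyl group stays in place across this step, which shows that a large drop in the number does not depend on changing that group, as it did in the earlier step with furan-2-yl. The two groups differ little in what is counted, with 2 heavy atoms in methoxy and 3 in dimethylamino, and each has 1 hydrogen-bond acceptor and 0 donors, while nothing available accounts for the size of the step.

The compounds shown leave open whether an unsubstituted amine, a methylamino group or a cyclic amine such as pyrrolidine on this carbon would give a similar number, so it cannot yet be said which feature of dimethylamino matters. They also leave open whether dimethylamino and furan-2-yl, each tied to a lower number on its own, would add up when carried together on the shared core.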